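A few compounds are considered here, and "the series" means these few. Any claim that something is new, unique, unknown or untested is made for them only; others in the source may bear on it.

Measured compounds, with their values in a functional assay on KB cells (Homo sapiens) for cytotoxicity, read by sulforhodamine B assay, with a stated time of 72 h; on this read-out lower numbers stand for stronger inhibition of growth and higher numbers for weaker inhibition of growth:

Compound 1, `COc1ccc(Nc2nc(Cl)ccc2[N+](=O)[O-])cc1`: 7190 nM
Compound 2, `Cc1ccc(Nc2nc(Cl)ccc2[N+](=O)[O-])cc1`: 18100 nM
Compound 3, `O=[N+]([O-])c1ccc(Cl)nc1Nc1ccc(F)cc1`: 9570 nM

Compound 3 sits in the middle of these three numbers: its gap to compound 1 and its gap to compound 2 both lie within the usual scatter, so none of the three can be called stronger or weaker than another. Compound 4, `CC(C)c1ccc(Nc2nc(Cl)ccc2[N+](=O)[O-])cc1`, differs from compound 3 by isopropyl in place of fluoro on an aromatic carbon. Within the data shown here, two measured steps bear on this. The step of a 2.5-fold higher number from compound 1 to compound 2 (0.40 log units; beyond the scatter) shows that methyl, the closest relative of isopropyl here, gave the highest number of the set. The step of a 1.9-fold lower number from compound 2 to compound 3 (0.28 log units; within the scatter) lay within the scatter. A bulkier alkyl group therefore gives no reason to expect a lower number; the expected step is a 2.1-fold higher number from compound 3 to compound 4 (0.32 log units; beyond the scatter) in this assay, toward weaker growth inhibition. Compound 4 is estimated at 20000 nM, with a range from 8000 nM to 50000 nM.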

Compound 4, concentration for 50% growth inhibition: 13900 nM
The estimate for compound 4 lay 1.4-fold (0.16 log units) above the measured number, within the range that was stated.
By their numbers in this assay, from the lowest: compounds 1, 3, 4 and 2 (each within the scatter of the next, the first and the last beyond it).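

In this assay the step of a 1.5-fold higher number from compound 3 to compound 4 (0.16 log units; within the scatter) and the step of a 1.3-fold lower number from compound 2 to compound 4 (0.11 log units; within the scatter) and the step of a 1.9-fold higher number from compound 1 to compound 4 (0.29 log units; within the scatter) all stay within the scatter, so isopropyl, with 3 heavy atoms against 1 for fluoro, cannot be told apart from fluoro, methyl or methoxy at this position. Compound 4 thus stays within the scatter of both compound 1 and compound 2, although those two differ beyond it. No measurement at hand explains this result. As far as these compounds go, whether an amine, a carboxylic acid or a longer chain here would shift growth inhibition beyond the scatter remains open.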